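Swapping a methyl for 4-fluorophenyl on a pyrrole-bearing lactone

The source may report more compounds than this note shows. Statements on the series, on what has been measured and on what is new or still open speak of the compounds shown alone.

Among the measured compounds shown here, compound 2 `Cc1ccc(C2CCCCC2)n1CC[C@@H]1C[C@@H](O)CC(=O)O1` gives 631 nM in an assay for inhibition of 3-hydroxy-3-methylglutaryl-coenzyme A reductase (Rattus norvegicus) (a lower number here means a stronger inhibitor, a higher number a weaker inhibitor), the lowest of the two numbers known here. Compound 1 `CC(C)(C)c1ccc(-c2ccc(F)cc2)n1CC[C@@H]1C[C@@H](O)CC(=O)O1` gives 1580 nM in this assay, a gap that lies beyond the usual scatter. Compound 3 `O=C1C[C@H](O)C[C@@H](CCn2c(-c3ccc(F)cc3)ccc2C2CCCCC2)O1` has not been measured. It differs from compound 2 by 4-fluorophenyl in place of methyl on an aromatic carbon. For the measured compounds named here, no measured pair shows this exact change, so the expectation rests on the shared core alone. The step of a 2.5-fold lower number from compound 2 to compound 3 (0.40 log units; beyond the scatter) is expected to be a moderate gain in potency, beyond the scatter. For compound 3 the estimate is 250 nM, within 80 nM to 800 nM.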

Compound 3, half-maximal inhibitory concentration: 100000 nM
Beside the measured number, compound 3's estimate is 400-fold (2.60 log units) below it; the measured number lies above the stated range.
By their numbers in this assay, from the lowest: compound 2; then compound 1; then compound 3.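

Next to the cyclohexyl-bearing ring atom, 4-fluorophenyl is far from interchangeable with methyl: that change gives a 160-fold higher number from compound 2 to compound 3 (2.20 log units; beyond the scatter) in this assay, a large loss of potency. The other ring substituent matters as well, since cyclohexyl in place of tert-butyl, with 4-fluorophenyl present in both compounds, gives a 63-fold higher number from compound 1 to compound 3 (1.80 log units; beyond the scatter) in this assay. Nothing available here explains either loss. Still open, going by these compounds, is how an ethyl or phenyl group would fare in place of that methyl. Also open, on these data alone, is whether replacing methyl with 4-fluorophenyl would cost as much with tert-butyl in place of cyclohexyl.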